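The source may report more compounds than this note shows. Statements on the series, on what has been measured and on what is new or still open speak of the compounds shown alone.

In a functional assay on MCF7 cells (Homo sapiens) for inhibition, read by fluorescence, with a stated time of 72 h (on this read-out lower numbers stand for stronger inhibition of growth and higher numbers for weaker inhibition of growth), compound 3 (`CCCCCCn1cnc2c(Nc3cccc(Cl)c3)nc(N[C@H]3CC[C@H](N)CC3)nc21`) gives 2700 nM. Compound 2 (`CC(C)=CCn1cnc2c(Nc3cccc(Cl)c3)nc(N[C@H]3CC[C@H](N)CC3)nc21`) gives 4200 nM, within the scatter of compound 3, while compound 1 (`COc1ccc(Nc2nc(N[C@H]3CC[C@H](N)CC3)nc3c2ncn3CCC(C)C)c(OC)c1`) gives 6300 nM, a higher number than compound 3 and beyond the scatter. Compound 4 (`CC(C)CCn1cnc2c(Nc3cccc(Cl)c3)nc(N[C@H]3CC[C@H](N)CC3)nc21`) differs from compound 3 by a single change, isopropyl in place of butyl on a saturated chain carbon, two bonds along the chain from an aromatic nitrogen. For the measured compounds named here, only one measured step alters this chain alone, a 1.6-fold lower number from compound 2 to compound 3 (0.19 log units; within the scatter), and it stays within the scatter. Compound 1 carries the same isopentyl chain as compound 4 but also differs from it elsewhere, so it offers no clean comparison. Going by the values given here, with the step to compound 3 at 2700 nM as the only guide, no change beyond the scatter is expected in this assay. The expected step is a 1.2-fold higher number from compound 3 to compound 4 (0.09 log units; within the scatter), which is an estimate and not a measurement. Compound 4 is expected at 3300 nM, with an estimated range from 1800 nM to 6000 nM.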

Compound 4, concentration for 50% growth inhibition: 2100 nM
The estimate for compound 4 lay 1.6-fold (0.20 log units) above the measured number; the range from low to high includes it.
By their numbers in this assay, from the lowest: compounds 4, 3, 2 and 1 (each within the scatter of the next, the first and the last beyond it).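

In this assay, the chain on a saturated chain carbon, two bonds along the chain from an aromatic nitrogen, tolerates branching: isopropyl in place of butyl gives a 1.3-fold lower number from compound 3 to compound 4 (0.11 log units; within the scatter) and no readable change. Isobutyl in place of 2-methylprop-1-en-1-yl gives a 2.0-fold lower number from compound 2 to compound 4 (0.30 log units; within the scatter) and also stays inside the scatter, so the hexyl, isopentyl and prenyl-type chains of compound 3, compound 4 and compound 2 cannot be told apart here. Compound 1 and compound 4 share the isopentyl chain. For the compounds shown here, the group on the nitrogen can now be read alone: 3-chlorophenyl in place of 2,4-dimethoxyphenyl gives a 3.0-fold lower number from compound 1 to compound 4 (0.48 log units; beyond the scatter) and is the only step here beyond the scatter.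

No evidence on hand accounts for these numbers. As far as these compounds go, whether a chain ending in an amine or a carboxylic acid would leave the number as unmoved remains open.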